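A Small Chain Change from Compound 2

This account rests on a few compounds, and the source may have more. Where it says the series, first, only, none or still open, it means among the compounds named here.

Measured so far in a functional assay on K562 cells (Homo sapiens) for antiproliferative activity, read by MTT assay, with a stated time of 48 h (a lower number here means a stronger inhibitor of growth, a higher number a weaker inhibitor of growth), are two compounds:
Compound 1 `CCOc1cc(NC(=O)CCCCCC(=O)Nc2cc(-c3ccccc3)ccc2N)cc2c1OCC([N+](=O)[O-])=C2` gives 3210 nM
Compound 2 `CCOc1cc(NC(=O)CCCCC(=O)Nc2ccccc2N)cc2c1OCC([N+](=O)[O-])=C2` gives 3680 nM

These two values lie within the usual scatter of repeated measurements, so neither compound can be ranked over the other. For the measured compounds named here, compound 2 therefore stands level with the only other measured compound, and that is all the numbers can show so far.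

Compound 3 `CCOc1cc(NC(=O)CCCCCC(=O)Nc2ccccc2N)cc2c1OCC([N+](=O)[O-])=C2` has not yet been measured. Its change from compound 2 is ((2-aminophenyl)carbamoyl)methyl in place of (2-aminophenyl)carbamoyl on a saturated chain carbon, four bonds along the chain from a carbonyl carbon and in words it puts ((2-aminophenyl)carbamoyl)methyl in place of (2-aminophenyl)carbamoyl on a saturated chain carbon, four bonds along the chain from a carbonyl carbon.

Going by the values given here, no measured pair shows this change alone, so the data give no direct size for it. Starting from compound 2 at 3680 nM no step beyond the scatter is expected in this assay and neither direction is favoured. The estimated step is a 1.1-fold lower number from compound 2 to compound 3 (0.03 log units; within the scatter) and it is expected to stay within the scatter. The estimate for compound 3 is 3400 nM with 1700 nM to 6800 nM as its expected range.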

Compound 3, concentration for 50% growth inhibition: 3960 nM
The estimate for compound 3 lay 1.2-fold (0.07 log units) below the measured number; the range from low to high includes it.
By their numbers in this assay, from the lowest: compounds 1, 2 and 3 (each within the scatter of the next).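

In this assay, for the compounds shown here, ((2-aminophenyl)carbamoyl)methyl in place of (2-aminophenyl)carbamoyl on a saturated chain carbon, four bonds along the chain from a carbonyl carbon, gives a 1.1-fold higher number from compound 2 to compound 3 (0.03 log units; within the scatter), the first direct reading of this change, and the two compounds stand level. Going by these compounds alone, compound 3 also gives the first direct reading on the aromatic ring, where hydrogen in place of phenyl on an aromatic carbon gives a 1.2-fold higher number from compound 1 to compound 3 (0.09 log units; within the scatter), so neither change, taken alone, moves the number beyond the scatter. Nothing measured apart from these growth numbers bears on this result.

Within the data shown here, these compounds cover only two chain lengths and a single group other than hydrogen on that aromatic carbon, so it remains open whether a still longer chain, or a fluorine atom or a carboxylic acid in place of the phenyl, would give a step beyond the scatter. Also open, as far as these compounds go, is what a hydroxyl group in place of the amino group of the 2-aminophenyl part would do in this assay.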